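Lengthening the ester of compound 2

The compounds below may be only part of what the source reports. "The series", "measured", "known", "first", "only" and "open" are said of these compounds alone.

Within the data shown here, in a functional assay on MCF7 cells (Homo sapiens) for cytotoxicity, read by MTT assay, with a stated time of 72 h (on this read-out higher numbers stand for weaker inhibition and lower numbers for stronger inhibition), compound 2 `COC(=O)c1sc2ncccc2c1Nc1cc(OC)c(OC)c(OC)c1` gives 2640 nM as the higher of the two numbers so far, and compound 1 `COC(=O)c1sc2nc(C)ccc2c1Nc1cc(OC)c(OC)c(OC)c1` gives 0.53 nM as the lower. Compound 3 `CCOC(=O)c1sc2ncccc2c1Nc1cc(OC)c(OC)c(OC)c1` has methyl in place of hydrogen on a saturated chain carbon bound to an oxygen next to a carbonyl group, turning methoxycarbonyl to ethoxycarbonyl methyl in place of hydrogen on a saturated chain carbon bound to an oxygen next to a carbonyl group in the process. Among the measured compounds shown here, the one measured step, a 5000-fold higher number from compound 1 to compound 2 (3.70 log units; beyond the scatter), is large but involves methyl on an aromatic carbon, a different change, so it gives no firm guide here. The expectation is therefore a 1.3-fold lower number from compound 2 to compound 3 (0.12 log units; within the scatter) in this assay with no step beyond the scatter. Compound 3 is estimated at 2000 nM (expected range 250 nM to 10000 nM).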

Compound 3, half-maximal inhibitory concentration: 5280 nM
Compound 3: middle estimate off by 2.6-fold (0.42 log units), on the low side, and the stated range covers the measured number.
By their numbers in this assay, from the lowest: compound 1; then compounds 2 and 3 (each within the scatter of the next).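

In this assay, the change from methoxycarbonyl to ethoxycarbonyl gives a 2.0-fold higher number from compound 2 to compound 3 (0.30 log units; within the scatter), so adding methyl at this place on the core of compound 2 does not shift the read-out beyond the scatter. This is the first step shown at the ester, and it offers no sign that this position is as sensitive as the aromatic carbon in a 5000-fold higher number from compound 1 to compound 2 (3.70 log units; beyond the scatter). Nothing available explains the result. Still open, as far as these compounds go, is whether a longer chain such as butyl, or a carboxylic acid in place of the ester, would stay within the scatter. Also open, from the compounds shown here alone, is whether ethoxycarbonyl would behave the same way on the core of compound 1.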